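A few compounds are considered here, and "the series" means these few. Any claim that something is new, unique, unknown or untested is made for them only; others in the source may bear on it.

Compound 3 `CCc1ccc(C(=O)c2oc3cc(-c4ccccc4)cc(O)c3c2C)cc1` carries a 4-ethylphenyl ketone on a shared core. In a functional assay on WI-38 VA13 cells (Homo sapiens) for cytotoxicity (on this read-out lower numbers stand for an effect already at smaller amounts and higher numbers for an effect only at larger amounts of compound), compound 3 gives only a limit, > 4 ug/mL. Compound 2 `Cc1c(C(=O)Cc2ccccc2)oc2cc(-c3ccccc3)cc(O)c12` also reaches only a limit in this assay, > 4 ug/mL. Compound 1 `Cc1ncsc1CCOC(=O)c1oc2cc(-c3ccccc3)cc(O)c2c1C`, by contrast, gives 0.055 ug/mL in this assay. The steps of an at least 72-fold higher number from compound 1 to compound 2 (1.86 log units; beyond the scatter) and an at least 72-fold higher number from compound 1 to compound 3 (1.86 log units; beyond the scatter) are both large, whereas a step that the two limits leave unreadable from compound 2 to compound 3 stays unreadable because of the limit of > 4 ug/mL in this assay, at which 2 of the 3 values shown sit. Compound 4 `COc1ccccc1C(=O)c1oc2cc(-c3ccccc3)cc(O)c2c1C` differs from compound 3 by 2-methoxyphenyl in place of 4-ethylphenyl on a carbonyl carbon. Among the compounds with values here, no measured step exchanges one aryl group for another on this carbonyl with a readable number, so the expected step that the limit leaves unreadable from compound 3 to compound 4 is no change beyond the scatter, and compound 4 is estimated at 6 ug/mL, within 2 ug/mL to 20 ug/mL, most likely again only a limit.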

Compound 4, half-maximal effective concentration: 0.09 ug/mL
Compound 4: the middle estimate sits 67-fold (1.82 log units) above what was measured; measured number outside the range, below it.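

On this carbonyl carbon, one aryl group cannot simply stand in for another: 2-methoxyphenyl in place of 4-ethylphenyl gives an at least 44-fold lower number from compound 3 to compound 4 (1.64 log units; beyond the scatter). In place of benzyl, 2-methoxyphenyl gives an at least 44-fold lower number from compound 2 to compound 4 (1.64 log units; beyond the scatter), and both of these steps start from a limit rather than a number: the limit of > 4 ug/mL in this assay, at which 2 of the 4 values shown sit. Against 2-(4-methyl-1,3-thiazol-5-yl)ethoxy, the same group gives a 1.6-fold higher number from compound 1 to compound 4 (0.21 log units; within the scatter), so a ketone without the thiazole can match the ester of compound 1.

As far as these compounds go, it stays open how 4-methoxyphenyl or 2-aminophenyl would read on this carbonyl carbon.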